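Compound 1 to compound 3: 3-methoxybenzyl to 2,6-dichlorobenzyl

The source may hold more compounds than are shown below. What is called first, only, known or untested is meant among the compounds shown, and "the series" means these compounds.

Values below come from a functional assay on DU-145 cells (Homo sapiens) for cytotoxicity, read by MTT assay (on this read-out lower numbers stand for stronger inhibition and higher numbers for weaker inhibition), as follows
- Compound 1 `COc1cccc(CSc2nnc([C@@H](C)c3ccc4cc(OC)ccc4c3)n2-c2ccc(Cl)cc2)c1` gives <= 400000 nM as a limit
- Compound 2 `COc1cccc(CSc2nnc([C@@H](C)c3ccc4cc(OC)ccc4c3)n2-c2ccc(F)cc2)c1` gives 19200 nM as a number
- Compound 3 `COc1ccc2cc([C@H](C)c3nnc(SCc4c(Cl)cccc4Cl)n3-c3ccc(Cl)cc3)ccc2c1` has no value yet

Going by these compounds, compound 1 carries <= 400000 nM as a limit and not as a number, so its place stays open. Its standing rests on the limit of <= 400000 nM in this assay, at which 1 of the 2 values shown sits, alone.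

The change to compound 3 reads 2,6-dichlorophenyl in place of 3-methoxyphenyl on a saturated chain carbon bound to a sulfur and amounts to 2,6-dichlorophenyl in place of 3-methoxyphenyl on a saturated chain carbon bound to a sulfur.

Within the data shown here, the only measured step is a step that the limit leaves unreadable from compound 1 to compound 2 for fluoro in place of chloro on an aromatic carbon. Among the measured compounds shown here, that is a different change with no readable size, so no measured step sets a size or direction for this one in this assay and none is argued here. For the measured compounds named here, the only true number available is compound 2 at 19200 nM as a loose anchor, and the range is kept wide.

The estimated step reads a step that the limit leaves unreadable from compound 1 to compound 3 and remains an expectation only. In this assay compound 3 is estimated at 25000 nM with an expected range from 6000 nM to 100000 nM around it.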

Compound 3, half-maximal inhibitory concentration: 36100 nM
Estimate against measurement, compound 3: 1.4-fold (0.16 log units) below, within the range that was stated.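

In this assay no new step can be read from compound 1 to compound 3, because compound 1 stands only as a limit: the limit of <= 400000 nM in this assay, at which 1 of the 3 values shown sits.

The compounds shown leave open how far 2,6-dichlorobenzyl in place of 3-methoxybenzyl moves the read-out, as no pair differing only in that place has a number on both sides.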